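Swapping a methyl for a nitrile on the aryl ring

This account rests on a few compounds, and the source may have more. Where it says the series, first, only, none or still open, it means among the compounds named here.

Compound 3 `Cc1ccc(-c2nnn(CC(=O)Nc3cc(C)nn3C3CCCCC3)n2)cc1` carries a 4-methylphenyl group on the shared core. In an assay on HEK293 cells for activation of Kir3.1/Kir3.2 (Homo sapiens), read by thallium flux (on this read-out lower numbers stand for smaller maximal responses and higher numbers for larger maximal responses), compound 3 reaches 86%. Its closest neighbour among the measured numbers is compound 1 `Cc1cc(NC(=O)Cn2nnc(-c3cc(Cl)cc(Cl)c3)n2)n(C2CCCCC2)n1`, which in this assay gives 82%; the two lie within the scatter of each other, as a number 4 percentage points higher from compound 1 to compound 3 (within the scatter) shows. Compound 2 `Cc1cc(NC(=O)Cn2nnc(-c3cccc(F)n3)n2)n(C2CCCCC2)n1` is reported in this assay only as a limit, > 83%, so no exact number exists for it; this is the limit of > 83% in this assay, at which 1 of the 3 values shown sits. Accordingly a number at least 1 percentage points higher from compound 1 to compound 2 (that floor lies within the scatter) is known only as a floor, and a step that the limit leaves unreadable from compound 2 to compound 3 cannot be read at all.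

Compound 4 `Cc1cc(NC(=O)Cn2nnc(-c3cccc(C#N)c3)n2)n(C2CCCCC2)n1` is the next variation: 3-cyanophenyl in place of 4-methylphenyl on an aromatic carbon. The two measured steps that replaced the aryl group, a number 4 percentage points higher from compound 1 to compound 3 (within the scatter) and a number at least 1 percentage points higher from compound 1 to compound 2 (that floor lies within the scatter), both stayed within or close to the scatter, so the aryl substituent has so far hardly moved the maximal response. The same is expected here. Compound 4 is estimated at 84% in this assay, with a likely range from 72% to 95%. The step this implies, a number 2 percentage points lower from compound 3 to compound 4 (within the scatter), is expected to fall within the scatter.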

Compound 4, largest response reached (Emax), in percent of the reference or control that the assay uses: 80%
Estimate against measurement, compound 4: 4 percentage points above; the range from low to high includes it.
By their numbers in this assay, from the lowest: compounds 4, 1 and 3 (each within the scatter of the next).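

The nitrile adds something the earlier aryl groups on this position did not show: 3-cyanophenyl brings a hydrogen-bond acceptor that 4-methylphenyl lacks, yet in this assay the swap gives a number 6 percentage points lower from compound 3 to compound 4 (within the scatter) and leaves the response within the scatter. The comparison with the 3,5-dichlorophenyl group gives the same picture, with a number 2 percentage points lower from compound 1 to compound 4 (within the scatter), so the nitrile separates from neither of the two exactly measured aryl groups. The comparison with the 6-fluoropyridin-2-yl group gives only a floor, a number at least 3 percentage points lower from compound 2 to compound 4 (that floor lies within the scatter), because that value is a limit of the assay and not a number: the limit of > 83% in this assay, at which 1 of the 4 values shown sits.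

The compounds shown leave open whether a group of a different kind on this position, such as an aryl ring carrying an amine or a carboxylic acid, or a longer alkyl chain in place of the aryl ring, would move the maximal response beyond the scatter. The concentration at which each compound reaches its response also lies outside what is shown here, so any difference among these aryl groups in that respect remains unknown.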